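This account rests on a few compounds, and the source may have more. Where it says the series, first, only, none or still open, it means among the compounds named here.

Measured so far in an ADME assay on BJ cells (Homo sapiens) for cytotoxicity, with a stated time of 72 h; a higher number here means that more compound is needed for the effect, a lower number that less compound is needed:
compound 1 `Cc1ccc(-c2nc3ccccc3s2)cc1NC(=O)c1cc([N+](=O)[O-])c(N2CCC(C(=O)O)CC2)cc1Cl`: > 25000 nM
compound 2 `O=C(Nc1nc2ccc(Cl)cc2s1)c1cc([N+](=O)[O-])ccc1Cl`: > 27000 nM
compound 3 `O=C(Nc1ccc(-c2ccccc2)cc1)c1cc([N+](=O)[O-])ccc1Cl`: > 27000 nM

For compound 3 the value > 27000 nM is a limit of the assay, not a number. Compound 1 likewise gives > 25000 nM, a limit. Compound 2 gives > 27000 nM, again a limit. The whole set sits at the ceiling: the limit of > 25000 nM in this assay, at which 1 of the 3 values shown sits, and (the limit of > 27000 nM in this assay, at which 2 of the 3 values shown sit). Compound 3 is therefore indistinguishable from compounds 1 and 2 in this assay, and nothing marks any of the three as more or less cytotoxic than the others.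

Compound 4 `O=C(Nc1ccc(Cl)cc1)c1cc([N+](=O)[O-])ccc1Cl` differs from compound 3 by chloro in place of phenyl on an aromatic carbon. Among the measured compounds shown here, no measured step between compounds differing in one place exists in this set, so no trend can be read from it. Given that every value so far is a limit, the step of a number no higher from compound 3 to compound 4 (the limit leaves the size open) is expected to be none beyond the scatter. Compound 4 is estimated at 27000 nM, with a range from 12000 nM to 60000 nM, and most probably the assay will again report only a limit rather than a number.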

Compound 4, half-maximal effective concentration: > 27000 nM
Compound 4: no number, only a limit; the forecaster's own chance of this, stated with the estimate: 85%; the middle value sits exactly at the limit.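

In this assay compound 3 and compound 4 both give only limits of the assay, not numbers, and the step of chloro in place of phenyl between them cannot be read. The compounds shown leave open whether any structure in this series reaches a measurable half-maximal effective concentration.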